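Benzyl-to-benzyl swap on an amidinocarbonyl pyrazine series

The source may report more compounds than this note shows. Statements on the series, on what has been measured and on what is new or still open speak of the compounds shown alone.

Measured so far:
compound 1 `NC(N)=NC(=O)c1nc(Cl)c(NCc2ccc(Cl)cc2)nc1N`: 46%
compound 2 `NC(N)=NC(=O)c1nc(Cl)c(Nc2ccccn2)nc1N`: "not determined" (no result reported)
compound 3 `NC(N)=NC(=O)c1nc(Cl)c(NCc2ccccc2F)nc1N`: not yet measured

Within the data shown here, in an assay for inhibition of acid-sensing ion channel 3 (Homo sapiens), read by patch clamp, tested at 1 uM (on this read-out lower numbers stand for less inhibition and higher numbers for more inhibition at the one concentration tested (going by the name of the read-out)), compound 1 gives 46%, the only number in the set; in this assay compound 2 gives "not determined" (no result reported), so compound 1 stands alone and cannot be ranked against anything.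

Compound 3 differs from compound 1 in one place: 2-fluorophenyl in place of 4-chlorophenyl on a saturated chain carbon bound to a nitrogen on an aromatic ring. Among the measured compounds shown here, no step between measured compounds is available to calibrate this change, so the expectation rests on compound 1 alone. The expected step from compound 1 to compound 3 is small, a number 8 percentage points lower from compound 1 to compound 3 (within the scatter), most likely not beyond the usual scatter, with a slight lean toward less inhibition.

For compound 3 the estimate in this assay is 38%, with a range from 15% to 60%.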

Compound 3, a percentage reported as inhibition, at one concentration (the size of the read-out at that concentration, not a potency): 26%
Beside the measured number, compound 3's estimate is 12 percentage points above it, and the stated range covers the measured number.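

Replacing 4-chlorophenyl with 2-fluorophenyl on a saturated chain carbon bound to a nitrogen on an aromatic ring gives, in this assay, a number 20 percentage points lower from compound 1 to compound 3 (beyond the scatter). Among these compounds, this is the first readable step, and it shows that inhibition at this position responds to a change in the aryl group. The heavy-atom count of 7, the ring type and the donor and acceptor counts are the same for both groups, so these counts do not separate them, and nothing measured here explains the step.

Among the compounds shown here, the single step changes both the halogen and its place on the ring, so it leaves open which of the two matters in this assay. Going by these compounds, how an unsubstituted phenyl, or a longer chain between the ring and the nitrogen, would read also remains open.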